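A few compounds are considered here, and "the series" means these few. Any claim that something is new, unique, unknown or untested is made for them only; others in the source may bear on it.

Working notes on the series.

The series is built on two cores. Compound 1 `COC(=O)N(C)CC#CCN1CCCC1` carries pyrrolidin-1-yl, and compound 2 `COC(=O)N(C)CC#CCn1ccnc1` carries 1H-imidazol-1-yl in its place; the change is 1H-imidazol-1-yl in place of pyrrolidin-1-yl on a saturated chain carbon bound to a triple-bonded carbon. Compound 3 `CCOC(=O)N(C)C(C)C#CCN1CCCC1` is the pyrrolidin-1-yl compound of the second core, and the difference between the two cores is not broken down here. Compound 4 `CCOC(=O)N(C)C(C)C#CCn1ccnc1` is not yet measured.

In a functional assay on the whole organism for antagonist activity, with Mus musculus as the target (on this read-out higher numbers stand for an effect only at larger amounts of compound and lower numbers for an effect already at smaller amounts), compound 1 gives > 10 mg/kg, which is a limit of the assay and not a number. In this assay compound 2 gives > 100 mg/kg, again a limit and not a number. The step that the two limits leave unreadable from compound 1 to compound 2 therefore cannot be sized, as the limit of > 10 mg/kg in this assay, at which 1 of the 3 values shown sits, and the limit of > 100 mg/kg in this assay, at which 1 of the 3 values shown sits, show. In this assay, within the data shown here, compound 3 gives 97 mg/kg, the only number in the set.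

Compound 4 differs from compound 3 by 1H-imidazol-1-yl in place of pyrrolidin-1-yl on a saturated chain carbon bound to a triple-bonded carbon, the same change as from compound 1 to compound 2. Because that earlier step is left unreadable by the limit of > 10 mg/kg in this assay, at which 1 of the 3 values shown sits, and (the limit of > 100 mg/kg in this assay, at which 1 of the 3 values shown sits), the expected size of a 3.1-fold higher number from compound 3 to compound 4 (0.49 log units; beyond the scatter) rests mainly on the position of compound 3. In this assay, among the measured compounds shown here, compound 3 gives 97 mg/kg, the one value in the set that is a number. For compound 4 the expected value in this assay is 300 mg/kg, with a range from 100 mg/kg to 1000 mg/kg, and a limit rather than a number is the more likely outcome.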

Compound 4, dose for half-maximal effect: 54 mg/kg
Estimate against measurement, compound 4: 5.6-fold (0.74 log units) above; the whole stated range lies above it.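

In this assay, 1H-imidazol-1-yl in place of pyrrolidin-1-yl on the core of compound 3 gives a 1.8-fold lower number from compound 3 to compound 4 (0.25 log units; within the scatter), so on this core the read-out does not tell the two groups apart. On the core of compound 1 the same change gives no readable step, because compound 1 stands at a limit of the assay and not at a number: the limit of > 10 mg/kg in this assay, at which 1 of the 4 values shown sits. Compound 2 also stands at a limit and not at a number, so the series holds one readable step on one core, which shows what the change does there but neither supports nor contradicts its carrying over from one core to the other: the limit of > 100 mg/kg in this assay, at which 1 of the 4 values shown sits.

The compounds shown leave open how piperidin-1-yl or a dimethylamino group would read on a saturated chain carbon bound to a triple-bonded carbon, and whether either would separate from the two groups on the core of compound 3. Among these compounds, also open is what any single part of the difference between the two cores contributes, for instance a methyl carbamate on the core of compound 3, since no one-place step links the two cores here.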